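Side-chain lengthening against a shared limit

The compounds below may be only part of what the source reports. "The series", "measured", "known", "first", "only" and "open" are said of these compounds alone.

Three compounds built on one shared core were examined in a functional assay on SW480 cells (Homo sapiens) for antiproliferative activity, read by MTT assay, with a stated time of 48 h; on this read-out lower numbers stand for stronger inhibition and higher numbers for weaker inhibition. Compound 1, `CC(CCO)n1cnc2c(Cl)ncnc21`, gives > 50000 nM in this assay, which is a limit of the assay and not a number. Compound 2, `CCCC(CCO)n1cnc2c(Cl)ncnc21`, gives > 50000 nM, again a limit. Compound 3, `CCCCC(CCO)n1cnc2c(Cl)ncnc21`, gives > 50000 nM, also a limit. The steps between them, a step that the two limits leave unreadable from compound 1 to compound 2, a step that the two limits leave unreadable from compound 1 to compound 3 and a step that the two limits leave unreadable from compound 2 to compound 3, therefore cannot be read in size, since every value shown sits at the limit of > 50000 nM in this assay, at which 3 of the 3 values shown sit. Compound 3 thus stands at the limit, and the two further values shown are limits as well.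

Compound 4, `CCCCCCC(CCO)n1cnc2c(Cl)ncnc21`, differs from compound 3 by ethyl in place of hydrogen on a saturated chain carbon, five bonds along the chain from an aromatic nitrogen. The measured steps that bear on this change are the chain extensions from compound 1 to compound 2 and from compound 2 to compound 3, both of which remain unreadable due to the limit of > 50000 nM in this assay, at which 3 of the 3 values shown sit. No step beyond the scatter can be inferred from them in either direction, and the most probable outcome for compound 4 is that this assay again reports only a limit. Compound 4 is therefore expected to give about 70000 nM, with a range from 20000 nM to 250000 nM. The step that the limit leaves unreadable from compound 3 to compound 4 is expected to stay within the scatter.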

Compound 4, half-maximal inhibitory concentration: 16700 nM
Compound 4: middle estimate off by 4.2-fold (0.62 log units), on the high side; the measured number lies below the stated range.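

In this assay, among these compounds, ethyl in place of hydrogen on a saturated chain carbon, five bonds along the chain from an aromatic nitrogen, brings an at least 2.9-fold lower number from compound 3 to compound 4 (0.47 log units; beyond the scatter), so lengthening this side chain can carry a compound clear of the limit, which the earlier compounds did not show. The longer chain of compound 4 stands out in the same way against the two shorter chains, giving an at least 2.9-fold lower number from compound 2 to compound 4 (0.47 log units; beyond the scatter), and also an at least 2.9-fold lower number from compound 1 to compound 4 (0.47 log units; beyond the scatter). These steps give only a minimum size and the steps among compound 1, compound 2 and compound 3 cannot be read at all, because the values of those three compounds are limits: the limit of > 50000 nM in this assay, at which 3 of the 4 values shown sit.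

Going by these compounds, whether a still longer chain would lower the number further in this assay stays open, since compound 4 alone carries a measured number. Also open, on these data alone, is how an amine or a carboxylic acid in place of the hydroxyl would read on the chain of compound 4.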